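Aryl urea pyrazole series: cytotoxicity on lung carcinoma cells

The compounds below may be only part of what the source reports. "The series", "measured", "known", "first", "only" and "open" are said of these compounds alone.

Measured so far:
compound 1, `O=C(Nc1cccc(-n2cc(-c3ccncc3)c(-c3ccc(Cl)c(O)c3)n2)c1)Nc1cccc(C(F)(F)F)c1`, > 32500 nM
compound 2, `COc1cc(-c2nn(-c3cccc(NC(=O)Nc4ccc(Cl)c(Cl)c4)c3)cc2-c2ccncc2)ccc1Cl`, > 50000 nM

Both values in a functional assay on HOP-62 cells (Homo sapiens) for inhibition, read by sulforhodamine B assay, with a stated time of 48 h (on this read-out higher numbers stand for lower toxicity in this test and lower numbers for higher toxicity in this test), are limits of the assay rather than numbers. For compound 2 the read-out stops at the limit of > 50000 nM in this assay, at which 1 of the 2 values shown sits. For compound 1 it stops at the limit of > 32500 nM in this assay, at which 1 of the 2 values shown sits. For the measured compounds named here, compound 2 therefore stands at a limit, and the only other value shown is a limit as well, so no ordering of the two can be drawn.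

Compound 3, `COc1cc(-c2nn(-c3cccc(NC(=O)Nc4cccc(C(F)(F)F)c4)c3)cc2-c2ccncc2)ccc1Cl`, differs from compound 2 by 3-(trifluoromethyl)phenyl in place of 3,4-dichlorophenyl on an amide-type nitrogen. Going by the values given here, no measured step of this kind is available. Since compound 1 already carries the 3-(trifluoromethyl)phenyl urea and sits at a limit, compound 3 is expected to remain at or near a limit, with a step of a number no higher from compound 2 to compound 3 (the limit leaves the size open) of no size beyond the scatter. The estimate for compound 3 is 50000 nM, with a range from 20000 nM to 120000 nM.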

Compound 3, concentration lethal to 50% of the cells: > 50000 nM
Compound 3 ended at the assay's limit (the forecaster's own chance of this, stated with the estimate: 80%); the middle value lies on the limit itself.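

No step can be read among compound 1, compound 2 and compound 3 in this assay: all three values are limits of the assay, not numbers. The compounds shown leave open whether 3-(trifluoromethyl)phenyl in place of 3,4-dichlorophenyl, or methyl in place of hydrogen on the oxygen, changes this read-out at all.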